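The compounds below may be only part of what the source reports. "The series", "measured", "known", "first", "only" and "open" are said of these compounds alone.

Of the compounds shown here, two have been measured in an assay on cells for antagonist activity at transient receptor potential cation channel subfamily V member 1 (Rattus norvegicus), read by scintillation counting, with a stated time of 10 min, in the presence of a further agent that is not named here; a higher number here means a weaker inhibitor, a lower number a stronger inhibitor. Compound 1 `C/C(=C\c1ccc(C(C)(C)C)cc1)C(=O)N[C@H](C)c1ccc(NS(C)(=O)=O)cc1` gives 46 nM. Compound 2 `C[C@@H](NC(=O)COc1ccc(C(C)(C)C)cc1)c1ccc(NS(C)(=O)=O)cc1` gives 96 nM, the higher of the two numbers, with a gap beyond the usual scatter. Compound 3 `C[C@@H](NC(=O)COc1ccc(C(C)(C)C)cc1)c1ccc(NS(C)(=O)=O)c(F)c1` has not been measured; it differs from compound 2 by fluoro in place of hydrogen on an aromatic carbon. For the measured compounds named here, no single-change step between measured compounds is available, so the expectation rests on the change alone: a modest fall in the number, toward a stronger inhibitor, is expected, as a 2.4-fold lower number from compound 2 to compound 3 (0.38 log units; beyond the scatter). Compound 3 is therefore estimated at 40 nM, within 12 nM to 130 nM.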

Compound 3, half-maximal inhibitory concentration: 71 nM
Beside the measured number, compound 3's estimate is 1.8-fold (0.25 log units) below it; low and high end bracket the measured number.
By their numbers in this assay, from the lowest: compounds 1, 3 and 2 (each within the scatter of the next, the first and the last beyond it).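

At this position, on an aromatic carbon ortho to a methanesulfonamido group, fluoro in place of hydrogen gives a 1.4-fold lower number from compound 2 to compound 3 (0.13 log units; within the scatter) in this assay. The position thus takes a fluoro, but the reading of compound 3 cannot be told apart from that of compound 2. Nothing measured here offers an explanation for this result. As far as these compounds go, whether chloro or methoxy on this same carbon would give a step beyond the scatter stays open. Also open, from the compounds shown here alone, is whether fluoro here would give a similar step on compound 1.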